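Cyclohexyl in place of isobutyl: what to expect for compound 3

The source may hold more compounds than are shown below. What is called first, only, known or untested is meant among the compounds shown, and "the series" means these compounds.

Among the compounds with values here, compound 2 `COc1cccc(-c2c(C)n(Cc3c(F)cccc3F)c(=O)n(C[C@H](N)CC(C)C)c2=O)c1F` gives 65.7 mL/min/kg in an in vivo ADME assay on the whole organism for pharmacokinetics, with Mus musculus as the target (on this read-out higher numbers stand for fast clearance and lower numbers for slow clearance), one of only two numbers available; compound 1 `COc1cccc(-c2c(C)n(Cc3c(F)cccc3F)c(=O)n(C[C@H](C)NCc3ccccc3)c2=O)c1F` gives 81.3 mL/min/kg, and the step of a 1.2-fold lower number from compound 1 to compound 2 (0.09 log units; within the scatter) separates them by no more than the scatter. Compound 3 `COc1cccc(-c2c(C)n(Cc3c(F)cccc3F)c(=O)n(C[C@H](N)C3CCCCC3)c2=O)c1F` carries cyclohexyl in place of isobutyl on a saturated chain carbon bound to an amine nitrogen and a saturated chain carbon. Within the data shown here, no measured step involves a change at this carbon, and the single step known, a 1.2-fold lower number from compound 1 to compound 2 (0.09 log units; within the scatter), stayed within the scatter. For compound 3 no step beyond the scatter is expected, a 1.0-fold lower number from compound 2 to compound 3 (0.00 log units; within the scatter). Compound 3 is therefore estimated at 65 mL/min/kg, with a range from 35 mL/min/kg to 120 mL/min/kg.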

Compound 3, clearance: 65.4 mL/min/kg
The estimate for compound 3 lay 1.0-fold (0.00 log units) below the measured number; low and high end bracket the measured number.
By their numbers in this assay, from the lowest: compounds 3, 2 and 1 (each within the scatter of the next).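

In this assay, within the data shown here, the first change at this carbon, cyclohexyl in place of isobutyl, gave a 1.0-fold lower number from compound 2 to compound 3 (0.00 log units; within the scatter) and so showed that a six-membered carbon ring can stand here with the number staying within the scatter. The wider exchange of amino(cyclohexyl)methyl for 1-(benzylamino)ethyl gave a 1.2-fold lower number from compound 1 to compound 3 (0.09 log units; within the scatter) and also stayed within the scatter. No measurement given here explains these results.

As far as these compounds go, whether a carboxylic acid, a hydroxyl group or a longer chain at this carbon would move the number beyond the scatter stays open. So does the effect of a methyl group on the amine of compound 3.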